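Ring size at the charged end of a long chain

The compounds below may be only part of what the source reports. "The series", "measured", "known", "first", "only" and "open" are said of these compounds alone.

Measured compounds:
compound 1 `Cc1cc(-n2cc(C(=O)Nc3cc(F)cc(F)c3)c(=O)c3ccc(N(C)C)nc32)ccc1OCCCCCCC[N+]12CCN(CC1)CC2` — 10.6%
compound 2 `CC[N+]1(CCCCCCCOc2ccc(-n3cc(C(=O)Nc4cc(F)cc(F)c4)c(=O)c4ccc(N(C)C)nc43)cc2C)CCCCC1` — 19.7%

In an assay on LX2 cells for inhibition of COL1A1 promoter (Homo sapiens), read by a luciferase reporter, with a stated time of 24 h, tested at 20 uM (a lower number here means a weaker effect, a higher number a stronger effect of the compound at the concentration tested), compound 2 gives the higher of the two numbers, but its nearest neighbour, compound 1, is only a number 9.1 percentage points higher from compound 1 to compound 2 (within the scatter) away, so the two cannot be told apart. Compound 3 `CC[N+]1(CCCCCCCOc2ccc(-n3cc(C(=O)Nc4cc(F)cc(F)c4)c(=O)c4ccc(N(C)C)nc43)cc2C)CCCC1` is not yet measured. It differs from compound 2 only at the far end of the chain: a group of 7 heavy atoms (6 carbon, 1 nitrogen; one five-membered non-aromatic ring with 1 hetero atom) in place of a group of 8 heavy atoms (7 carbon, 1 nitrogen; one six-membered non-aromatic ring with 1 hetero atom), on a saturated chain carbon, seven bonds along the chain from an oxygen on an aromatic ring. For the measured compounds named here, the one step seen so far, from compound 1 to compound 2, changed that same end group and moved the read-out by a number 9.1 percentage points higher from compound 1 to compound 2 (within the scatter), which is within the scatter. The change to compound 3 is smaller, so no step beyond the scatter is expected, in either direction. The expected step of a number 2.7 percentage points lower from compound 2 to compound 3 (within the scatter) is therefore small, and compound 3 is estimated at 17%, between 5% and 30%.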

Compound 3, a percentage reported as inhibition, at one concentration (the size of the read-out at that concentration, not a potency): 44.7%
Compound 3: middle estimate off by 27.7 percentage points, on the low side; the measured number lies above the stated range.
By their numbers in this assay, from the lowest: compounds 1 and 2 (each within the scatter of the next); then compound 3.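

In this assay the ring at the charged end of the chain now clearly matters: the five-membered ring in place of the six-membered ring gives a number 25 percentage points higher from compound 2 to compound 3 (beyond the scatter) and so moves the read-out beyond the scatter, which the earlier step between compound 1 and compound 2 did not do. Against the two-ring end group, the same five-membered ring gives a number 34.1 percentage points higher from compound 1 to compound 3 (beyond the scatter) so this place on the chain can respond strongly to the end group. Nothing available here accounts for the gain from the five-membered ring.

Still open, on these data alone, is how a four-membered or seven-membered ring at the same place would read against the five-membered one. Also open, as far as these compounds go, is whether a methyl group could stand in for the ethyl group on the ring nitrogen without losing the gain.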